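The compounds below may be only part of what the source reports. "The series", "measured", "known", "first", "only" and "open" are said of these compounds alone.

Measured so far:
compound 1, `O=C(COc1ccc2c(=O)c(-c3ccccc3)coc2c1)Nc1ccc2ccccc2c1`; in a functional assay on NCI-H661 cells (Homo sapiens) for antiproliferative activity, read by MTT assay, with a stated time of 72 h (a lower number here means a stronger inhibitor of growth, a higher number a weaker inhibitor of growth), compound 1 gives > 10000 nM, a limit of the assay.
compound 2, `O=C(COc1ccc2c(=O)c(-c3ccccc3)coc2c1)Nc1ccc(F)cc1`; in this assay compound 2 gives > 10000 nM, again a limit of the assay.

Compound 2 thus stands at the limit, as does compound 1. The step that the two limits leave unreadable from compound 1 to compound 2 cannot be read from the two limits. Both measured values sit at the limit of > 10000 nM in this assay, at which 2 of the 2 values shown sit.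

Compound 3, `COc1ccc(NC(=O)COc2ccc3c(=O)c(-c4ccccc4)coc3c2)cc1`, differs from compound 2 by methoxy in place of fluoro on an aromatic carbon. Among the compounds with values here, the only measured step concerns a different change at the amide-type nitrogen and its size is not readable, so no direction beyond the scatter is expected for the step from compound 2 to compound 3 in this assay. The step that the limit leaves unreadable from compound 2 to compound 3 is the estimate, with compound 3 most likely remaining at the limit as well. Compound 3 is estimated at 15000 nM, between 3000 nM and 60000 nM.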

Compound 3, concentration for 50% growth inhibition: 9530 nM
Estimate against measurement, compound 3: 1.6-fold (0.20 log units) above, and the stated range covers the measured number.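

With methoxy on this aromatic carbon, para to a large group, the series gives its first number that is not a limit: in this assay compound 3 gives 9530 nM. The change from fluoro to methoxy amounts to an at least 1.0-fold lower number from compound 2 to compound 3 (0.02 log units; that floor lies within the scatter), and the change at the amide-type nitrogen to an at least 1.0-fold lower number from compound 1 to compound 3 (0.02 log units; that floor lies within the scatter), so neither step shows a gain beyond the scatter. The readout therefore remains close to the assay limit, which still holds most of the series: the limit of > 10000 nM in this assay, at which 2 of the 3 values shown sit.

On these data alone, how far the true steps to compound 3 extend remains open, since both compared values are limits. Also open, as far as these compounds go, is whether an ethoxy group, a hydroxyl or an amine on the same aromatic carbon would give a number clearly beyond the scatter from that of compound 3.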